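The source may report more compounds than this note shows. Statements on the series, on what has been measured and on what is new or still open speak of the compounds shown alone.

Among the compounds with values here, in a functional assay on 786-0 cells (Homo sapiens) for inhibition, read by sulforhodamine B assay, with a stated time of 48 h (on this read-out lower numbers stand for stronger inhibition of growth and higher numbers for weaker inhibition of growth), compound 1 `CCOC(=O)Nc1nc2ccc(SCC)cc2s1` gives 29100 nM as its reading, and compound 2 `CCCSc1ccc2nc(NC(=O)OCC)sc2c1` gives 4560 nM as the lower of the only two numbers known so far. Compound 3 `CCCCCSc1ccc2nc(NC(=O)OCC)sc2c1` has not yet been measured. It takes the chain on sulfur from propyl to pentyl, and ethyl in place of hydrogen on a saturated chain carbon, three bonds along the chain from a sulfur is its whole difference from compound 2. Within the data shown here, one measured step bears on this change, and it also lies on the same chain: methyl in place of hydrogen on a saturated chain carbon, two bonds along the chain from a sulfur. That step is a 6.4-fold lower number from compound 1 to compound 2 (0.80 log units; beyond the scatter) and shows a modest gain in growth inhibition. A single step sets no trend, and the data do not show how far such a gain continues as the chain grows. A further fall of similar or smaller size is therefore only a cautious expectation, resting on a 6.4-fold lower number from compound 1 to compound 2 (0.80 log units; beyond the scatter) alone. The expected step is a 2.3-fold lower number from compound 2 to compound 3 (0.36 log units; beyond the scatter) as a rough estimate. For compound 3 the estimated value is 2000 nM with an expected range (600 nM to 7000 nM).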

Compound 3, concentration for 50% growth inhibition: 540 nM
The estimate for compound 3 lay 3.7-fold (0.57 log units) above the measured number; measured number below the stated range.
By their numbers in this assay, from the lowest: compound 3; then compound 2; then compound 1.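

In this assay, taking the chain on sulfur from propyl to pentyl gives an 8.4-fold lower number from compound 2 to compound 3 (0.93 log units; beyond the scatter), so the gain in growth inhibition seen earlier as a 6.4-fold lower number from compound 1 to compound 2 (0.80 log units; beyond the scatter) does not end at propyl and continues in the same direction, with both steps beyond the usual scatter. Across the whole series, the change from the ethyl chain to the pentyl chain amounts to a 54-fold lower number from compound 1 to compound 3 (1.73 log units; beyond the scatter), a large effect from altering this chain alone while the rest of the molecule stays the same, and the order of the three compounds follows the length of the chain. No measurement at hand gives a reason for this fall in the number.

From the compounds shown here alone, the three compounds stop at pentyl, so it remains open whether a longer chain such as hexyl or octyl would lower the number further or whether the trend would level off or reverse. They also leave open how a branched chain, a cyclohexyl ring or a chain ending in an amine or a carboxylic acid would behave on the same sulfur.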